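The compounds below may be only part of what the source reports. "The series", "measured", "known", "first", "only" and "open" are said of these compounds alone.

In a functional assay on SK-BR-3 cells (Homo sapiens) for antiproliferative activity, read by MTT assay, with a stated time of 72 h (a higher number here means a weaker inhibitor, a lower number a stronger inhibitor), compound 1 `CCN1CCN(c2cc(C)c3cc(NC(=O)c4ccccc4F)ccc3n2)CC1` gives 38100 nM, and compound 2 `CCN1CCN(c2cc(C)c3cc(NC(=O)c4cccnc4)ccc3n2)CC1` gives 10600 nM. Going by the values given here, on these two numbers compound 2 stands lowest, with compound 1 as its only neighbour, reached through the step of a 3.6-fold lower number from compound 1 to compound 2 (0.56 log units; beyond the scatter). Compound 3 `CCN1CCN(c2cc(C)c3cc(NC(=O)c4cccc(Br)c4)ccc3n2)CC1` differs from compound 2 in one place: 3-bromophenyl in place of pyridin-3-yl on a carbonyl carbon. Among the compounds with values here, the only measured step that bears on this change is the one from compound 1 to compound 2, where a carbon-only aromatic ring gave way to the pyridin-3-yl ring and the number fell beyond the scatter. Within the data shown here, compound 3 puts a carbon-only ring back on the carbonyl carbon, so a move in the opposite direction is expected, though the substituent on that ring differs from the one in compound 1. The step of a 2.1-fold higher number from compound 2 to compound 3 (0.32 log units; beyond the scatter) is therefore expected to run upward by a modest amount. Compound 3 is estimated at 22000 nM in this assay, within a range of 7000 nM to 65000 nM.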

Compound 3, half-maximal inhibitory concentration: 13300 nM
Compound 3: the middle estimate sits 1.7-fold (0.22 log units) above what was measured; the range from low to high includes it.
By their numbers in this assay, from the lowest: compounds 2 and 3 (each within the scatter of the next); then compound 1.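

In this assay the step of a 1.3-fold higher number from compound 2 to compound 3 (0.10 log units; within the scatter) shows that, on this carbonyl carbon, pyridin-3-yl and 3-bromophenyl cannot be told apart, so a ring of carbon only does not by itself bring back the higher number of compound 1. The step of a 2.9-fold lower number from compound 1 to compound 3 (0.46 log units; beyond the scatter) shows that a change between two carbon-only rings can also reach beyond the scatter, which makes the earlier step less clearly a matter of the ring nitrogen. Nothing measured here accounts for either step.

Going by these compounds, whether the bromine itself or the place of the substituent matters stays open, as 2-fluorophenyl and 3-bromophenyl differ in both. Also open, on these data alone, is how a phenyl ring bearing an amine or a carboxylic acid, or a saturated cyclohexyl ring, would read on this carbonyl carbon.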